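The compounds below may be only part of what the source reports. "The series", "measured", "known", "first", "only" and "open" are said of these compounds alone.

Compound 1 `Oc1c(-c2nc(C(O)c3ccccc3)n[nH]2)ncc2cccnc12` gives 1.9 mL.min-1.g-1
Compound 2 `Cc1n[nH]c(-c2ncc3c(N(C)C)ccnc3c2O)n1` gives 14 mL.min-1.g-1

Both numbers come from an ADME assay on microsomes from liver (Mus musculus) for metabolic stability; on this read-out higher numbers stand for fast clearance and lower numbers for slow clearance. Compound 2 holds the higher of the two numbers, and its gap to compound 1 lies beyond the usual scatter. Compound 3 `COc1ccccc1-c1ccnc2c(O)c(-c3nc(C)n[nH]3)ncc12` carries 2-methoxyphenyl in place of dimethylamino on an aromatic carbon. Within the data shown here, no measured pair shows this swap, so any expectation here is loose. The expected change is a modest rise in clearance, near the edge of the scatter (a 2.0-fold higher number from compound 2 to compound 3 (0.30 log units; within the scatter)). Compound 3 is expected to give 28 mL.min-1.g-1 (estimated range 11 mL.min-1.g-1 to 70 mL.min-1.g-1).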

Compound 3, intrinsic clearance in microsomes: 0.8 mL.min-1.g-1
The estimate for compound 3 lay 35-fold (1.54 log units) above the measured number; the measured number lies below the stated range.
By their numbers in this assay, from the lowest: compound 3; then compound 1; then compound 2.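

This position strongly shapes the read-out: on this aromatic carbon, opposite the ring nitrogen, 2-methoxyphenyl in place of dimethylamino brings an 18-fold lower number from compound 2 to compound 3 (1.24 log units; beyond the scatter) in this assay. The earlier compounds shown here offered no pair that tested this place, and this single pair now links the larger aromatic group to slower clearance. Nothing measured here explains the fall.

Still open, on these data alone, is whether the lower number needs the methoxy group or would also come with a plain phenyl. A cyclic amine such as morpholine at this carbon would show how far the high number goes with amines generally.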